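The source may report more compounds than this note shows. Statements on the series, on what has been measured and on what is new or still open speak of the compounds shown alone.

Values in a functional assay on MCF7 cells (Homo sapiens) for antiproliferative activity; a higher number here means a weaker inhibitor, a lower number a stronger inhibitor:

- compound 1 `CC(C)=CCc1cc(C(=O)Nc2cc3ccc(OCCCN4CCCC4)c(C)c3oc2=O)ccc1O`: 990 nM
- compound 2 `CC(C)=CCc1cc(C(=O)Nc2cc3ccc(OCCCNCC(C)C)c(C)c3oc2=O)ccc1O`: 1320 nM
- compound 3 `CC(C)=CCc1cc(C(=O)Nc2cc3ccc(OCCCN(C)C(C)C)c(C)c3oc2=O)ccc1O`: 1050 nM

Compound 3, at 1050 nM, cannot be told apart from the other two compounds. The steps linking it to them are small: a 1.1-fold higher number from compound 1 to compound 3 (0.03 log units; within the scatter) and a 1.3-fold lower number from compound 2 to compound 3 (0.10 log units; within the scatter). The remaining step, a 1.3-fold higher number from compound 1 to compound 2 (0.12 log units; within the scatter), is just as small.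

The next compound is compound 4 `CC(C)=CCc1cc(C(=O)Nc2cc3ccc(OCCCNCC(=O)O)c(C)c3oc2=O)ccc1O`. Here (carboxymethyl)amino stands in place of isopropyl(methyl)amino, on the same saturated chain carbon, three bonds along the chain from an oxygen on an aromatic ring: (carboxymethyl)amino in place of isopropyl(methyl)amino on a saturated chain carbon, three bonds along the chain from an oxygen on an aromatic ring.

All three measured steps exchange one amine for another at this place, and none reaches beyond the scatter. Yet no measured compound carries a carboxymethyl group, so those steps are only a loose guide. The flat values, such as compound 3 at 1050 nM, leave the direction open, and a higher number seems the likelier outcome for so different a group.

The expected step in this assay is a 2.9-fold higher number from compound 3 to compound 4 (0.46 log units; beyond the scatter). For compound 4 the estimated value is 3000 nM, with an expected range of 1000 nM to 12000 nM.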

Compound 4, half-maximal inhibitory concentration: 18100 nM
Compound 4: middle estimate off by 6.0-fold (0.78 log units), on the low side; the measured number lies above the stated range.
By their numbers in this assay, from the lowest: compounds 1, 3 and 2 (each within the scatter of the next); then compound 4.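

In this assay, the three amines with only carbon groups on the nitrogen gave values within the scatter of one another, which made this position look undemanding, but that holds only for those amines. Placing (carboxymethyl)amino here gives a 17-fold higher number from compound 3 to compound 4 (1.24 log units; beyond the scatter) and, against the pyrrolidin-1-yl compound, an 18-fold higher number from compound 1 to compound 4 (1.26 log units; beyond the scatter), so the position does respond to what it carries, and compound 4 is a clearly weaker inhibitor than the other three; carboxy in place of isopropyl on a saturated chain carbon bound to an amine nitrogen likewise gives a 14-fold higher number from compound 2 to compound 4 (1.14 log units; beyond the scatter) in the closest comparison. No measurement available here accounts for this weakening.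

The compounds shown cannot say whether the carboxylic acid itself is what matters. A methyl ester or a primary amide in place of carboxy would test that, and a longer chain carrying the carboxylic acid would show whether its distance from the amine nitrogen counts.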